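A few compounds are considered here, and "the series" means these few. Any claim that something is new, unique, unknown or untested is made for them only; others in the source may bear on it.

Compound 1 `COc1cc(-c2nc(-c3ccccc3)[nH]c2-c2ccnc(NCCCNS(=O)(=O)c3ccccc3)n2)ccc1Cl` gives 7470 nM
Compound 2 `O=S(=O)(NCCCNc1nccc(-c2[nH]c(-c3ccccc3)nc2-c2ccc(F)c(O)c2)n1)c1ccccc1` gives 9580 nM

Both numbers come from a functional assay on LOX IMVI cells (Homo sapiens) for cytotoxicity, read by MTT assay, with a stated time of 24 h (a lower number here means a stronger inhibitor, a higher number a weaker inhibitor), and lie within the usual scatter of each other, so compound 2 stands level with compound 1. Compound 3 `O=S(=O)(NCCCNc1nccc(-c2[nH]c(-c3ccccc3)nc2-c2ccc(Cl)c(O)c2)n1)c1ccccc1` differs from compound 2 by a single atom swap, chloro in place of fluoro on an aromatic carbon, ortho to a hydroxy group and para to a large group. Among the measured compounds shown here, only one measured step bears on this swap: a 1.3-fold higher number from compound 1 to compound 2 (0.11 log units; within the scatter). That step exchanged the same two halogens in the opposite direction, with a methoxy becoming a hydroxy as well, and it stayed within the scatter. No change beyond the scatter is therefore expected in this assay, and the estimated step is a 1.1-fold lower number from compound 2 to compound 3 (0.05 log units; within the scatter). For compound 3 the expected value is 8500 nM, with an estimated range of 4000 nM to 17000 nM.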

Compound 3, half-maximal inhibitory concentration: 2630 nM
Compound 3: the middle estimate sits 3.2-fold (0.51 log units) above what was measured; the whole stated range lies above it.
By their numbers in this assay, from the lowest: compound 3; then compounds 1 and 2 (each within the scatter of the next).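

Chloro in place of fluoro, ortho to a hydroxy group, gives a 3.6-fold lower number from compound 2 to compound 3 (0.56 log units; beyond the scatter) in this assay and so shows that this single atom can shift the result by a modest step beyond the scatter. With chloro kept in place, hydrogen in place of methyl on the oxygen gives a 2.8-fold lower number from compound 1 to compound 3 (0.45 log units; beyond the scatter) as a second modest step beyond the scatter, so the hydroxy group also counts here. The earlier step changed both places at once, stayed within the scatter and showed neither effect.

Nothing shown explains why chloro with a hydroxy group gives the lowest number of the three. From the compounds shown here alone, whether bromo or a plain hydrogen in this place, or an amine in place of the hydroxy group, would move the number further remains open.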